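The source may hold more compounds than are shown below. What is called first, only, known or untested is meant among the compounds shown, and "the series" means these compounds.

Compound 2 `COC(=O)c1c(Nc2ccc(F)cc2)sc(C(=O)c2ccc(OC)cc2)c1C` stands lowest of the two measured numbers in a functional assay, with a stated time of 150 min, tested at 25 ug/mL; on this read-out lower numbers stand for a weaker effect and higher numbers for a stronger effect at the one concentration tested: compound 2 gives 20.2%, whereas compound 1 `COC(=O)c1c(Nc2ccccc2)sc(C(=O)c2ccc(OC)cc2)c1C` gives 36.9%, a gap beyond the scatter. Among the compounds with values here, the only measured step, a number 16.7 percentage points lower from compound 1 to compound 2 (beyond the scatter), concerns hydrogen to fluoro and so bears only indirectly on compound 3 `COC(=O)c1c(Nc2ccc(Cl)cc2)sc(C(=O)c2ccc(OC)cc2)c1C`, which differs from compound 2 by chloro in place of fluoro on an aromatic carbon. Within the data shown here, with no direct precedent, a change within the scatter or a small further fall is expected, and the step is estimated as a number 2.2 percentage points lower from compound 2 to compound 3 (within the scatter). Compound 3 is therefore expected near 18%, within 8% to 30%.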

Compound 3, a percentage reported as activity, at one concentration (the size of the read-out at that concentration, not a potency): "not active" (no number reported)
Compound 3: no number reported, and the estimate cannot be compared.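

Within the data shown here, compound 3 is reported as "not active" with no number in this assay, so no step from compound 2 to compound 3 can be read. Nothing shown here explains this result. The compounds shown leave open how far chloro in place of fluoro shifts the read-out.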